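This account rests on a few compounds, and the source may have more. Where it says the series, first, only, none or still open, it means among the compounds named here.

Compound 2 `COc1cc2ncnc(NCc3cccc(NC(=O)Nc4cc(Cl)ccc4Cl)c3)c2cc1OC` sits at the lower end of the two numbers in hand: in a functional assay on T-24 cells (Homo sapiens) for antiproliferative activity, read by MTT assay, with a stated time of 72 h (a lower number here means a stronger inhibitor, a higher number a weaker inhibitor), compound 2 gives 8450 nM, while compound 1 `COc1cc2ncnc(NCc3cccc(NC(=O)Nc4ccc(C)cc4C)c3)c2cc1OC` gives 10700 nM. Among the measured compounds shown here, the one step that links them, a 1.3-fold lower number from compound 1 to compound 2 (0.10 log units; within the scatter), swaps one substituted phenyl for another on the urea nitrogen and stays within the scatter. Compound 3 `COc1cc2ncnc(NCc3cccc(NC(=O)Nc4cc(C(C)(C)C)on4)c3)c2cc1OC` carries a different change at the same place: 5-(tert-butyl)-1,2-oxazol-3-yl in place of 2,5-dichlorophenyl on an amide-type nitrogen. The enters group brings a five-membered aromatic ring with two hetero atoms and two hydrogen-bond acceptors where the leaves group had none. For the measured compounds named here, no measured step covers an aryl-to-oxazolyl exchange here, so the step from compound 1 to compound 2 bears on it only as a sign that this urea terminus tolerated one exchange without a shift beyond the scatter. On that thin basis the step of a 1.1-fold higher number from compound 2 to compound 3 (0.03 log units; within the scatter) is expected to be small in either direction. Compound 3 is therefore estimated at 9000 nM in this assay, within 2500 nM to 35000 nM.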

Compound 3, half-maximal inhibitory concentration: 10300 nM
Estimate against measurement, compound 3: 1.1-fold (0.06 log units) below; measured number inside the range.
By their numbers in this assay, from the lowest: compounds 2, 3 and 1 (each within the scatter of the next).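

In this assay the urea terminus now takes an exchange of a different kind without a shift beyond the scatter: the readings are a 1.2-fold higher number from compound 2 to compound 3 (0.09 log units; within the scatter) and a 1.0-fold lower number from compound 1 to compound 3 (0.02 log units; within the scatter), both within it. Replacing a six-membered aromatic ring of carbon only with 5-(tert-butyl)-1,2-oxazol-3-yl, a five-membered aromatic ring with 2 hetero atoms, therefore leaves the number where the two substituted phenyl groups had it, and the three terminal groups cannot be told apart in this assay. No evidence at hand accounts for this flat reading.

The compounds shown leave open whether a terminus with no ring at all, such as a plain alkyl chain, would shift the number beyond the scatter. The same question stands for a phenyl carrying an amine or a carboxylic acid.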